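The source may hold more compounds than are shown below. What is called first, only, known or untested is meant among the compounds shown, and "the series" means these compounds.

Compound 1 `Oc1ccc(C(c2c[nH]c3ccc(Br)cc23)c2c[nH]c3ccc(Br)cc23)cc1` gives 9000 nM in a functional assay on A549 cells (Homo sapiens) for inhibition, read by MTT assay, with a stated time of 48 h; on this read-out higher numbers stand for weaker inhibition and lower numbers for stronger inhibition.
Compound 2 `COc1ccc(C(c2c[nH]c3ccc(Br)cc23)c2c[nH]c3ccc(Br)cc23)cc1OC` gives 12000 nM.
Compound 3 `Brc1ccc2[nH]cc(C(c3c[nH]c4ccc(Br)cc34)C3CCCCC3)c2c1` gives 5500 nM.

Among these three, compound 1 holds the second highest number, with both neighbours close: the steps of a 1.3-fold higher number from compound 1 to compound 2 (0.12 log units; within the scatter) and a 1.6-fold lower number from compound 1 to compound 3 (0.21 log units; within the scatter) stay within the scatter, and only a 2.2-fold lower number from compound 2 to compound 3 (0.34 log units; beyond the scatter) reaches a modest size beyond it. Compound 4 `O=[N+]([O-])c1ccc(C(c2c[nH]c3ccc(Br)cc23)c2c[nH]c3ccc(Br)cc23)cc1` differs from compound 1 by nitro in place of hydroxy on an aromatic carbon. Going by the values given here, no measured step puts a nitro group in place, so the only guidance comes from those two steps away from compound 1, which show that exchanging the group on this arm has so far moved the number little. For compound 4 the expected step is therefore no change at the digits printed from compound 1 to compound 4 (within the scatter), within the scatter, and the estimated value is 9000 nM with a range from 4000 nM to 20000 nM.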

Compound 4, half-maximal inhibitory concentration: 5500 nM
Compound 4: middle estimate off by 1.6-fold (0.21 log units), on the high side, and the stated range covers the measured number.
By their numbers in this assay, from the lowest: compounds 3, 4, 1 and 2 (each within the scatter of the next, the first and the last beyond it).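

Nitro in place of hydroxy gives a 1.6-fold lower number from compound 1 to compound 4 (0.21 log units; within the scatter) in this assay, so at this place on the ring, para to a large group, a group with no hydrogen-bond donor keeps the number within the scatter. The 4-nitrophenyl arm gives no change at the digits printed from compound 3 to compound 4 (within the scatter) against the cyclohexyl arm. Against the 3,4-dimethoxyphenyl arm it gives a 2.2-fold lower number from compound 2 to compound 4 (0.34 log units; beyond the scatter) and this modest step is beyond the scatter, matching the one seen for compound 3.

On these data alone, whether an amine or a carboxylic acid on this ring would move the number stays open. Nothing given here explains these numbers.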